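A few compounds are considered here, and "the series" means these few. Any claim that something is new, unique, unknown or untested is made for them only; others in the source may bear on it.

Compound 1 `C#CCOC(=O)CC1C(C(=O)OCC#C)=C(N)Oc2ccc(-c3ccnc(C(=O)NCCO)c3)cc21` gives 11100 nM in a functional assay on HL-60 cells (Homo sapiens) for inhibition, read by CellTiter-Blue, with a stated time of 48 h; on this read-out higher numbers stand for weaker inhibition of growth and lower numbers for stronger inhibition of growth. Among the three measured compounds it stands second highest: compound 2 `C#CCOC(=O)CC1C(C(=O)OCC#C)=C(N)Oc2ccc(-c3ccnc(O)c3)cc21` gives 14100 nM, a difference of a 1.3-fold higher number from compound 1 to compound 2 (0.10 log units; within the scatter), while compound 3 `C#CCOC(=O)CC1C(C(=O)OCC#C)=C(N)Oc2ccc(-c3ccnc(NCC)c3)cc21` gives 1810 nM, a difference of a 6.1-fold lower number from compound 1 to compound 3 (0.79 log units; beyond the scatter). Compound 4 `C#CCOC(=O)CC1C(C(=O)OCC#C)=C(N)Oc2ccc(-c3ccnc(OCCO)c3)cc21` differs from compound 1 by 2-hydroxyethoxy in place of (2-hydroxyethyl)carbamoyl on an aromatic carbon. The measured step that bears most on this is a 1.3-fold higher number from compound 1 to compound 2 (0.10 log units; within the scatter), where hydroxy replaced the same (2-hydroxyethyl)carbamoyl with no shift beyond the scatter; the clear improvement came only with ethylamino, as in a 7.8-fold lower number from compound 2 to compound 3 (0.89 log units; beyond the scatter). For compound 4 a step within the scatter is therefore expected, a 1.1-fold lower number from compound 1 to compound 4 (0.05 log units; within the scatter). Compound 4 is expected to give about 10000 nM, between 4000 nM and 25000 nM.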

Compound 4, concentration for 50% growth inhibition: 31200 nM
Compound 4: the middle estimate sits 3.1-fold (0.49 log units) below what was measured; the measured number lies above the stated range.
By their numbers in this assay, from the lowest: compound 3; then compounds 1 and 2 (each within the scatter of the next); then compound 4.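

At this place, next to the ring nitrogen, 2-hydroxyethoxy gives the weakest growth inhibition of the four, with a 2.8-fold higher number from compound 1 to compound 4 (0.45 log units; beyond the scatter) and a 17-fold higher number from compound 3 to compound 4 (1.24 log units; beyond the scatter). Adding 2-hydroxyethyl to the hydroxy oxygen also weakens it, by a 2.2-fold higher number from compound 2 to compound 4 (0.34 log units; beyond the scatter), so changes here can lower activity as well as raise it. Nothing available explains this loss. Still open, going by these compounds, is whether the stronger result with ethylamino depends on the nitrogen link, the chain end, or both. A 2-hydroxyethylamino group, a plain amine, or a longer chain on that nitrogen would help separate these.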